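A methylimidazole in place of the carbamoylmethyl chain

The compounds below may be only part of what the source reports. "The series", "measured", "known", "first", "only" and "open" are said of these compounds alone.

Compound 2 `CC(C)C(CC(N)=O)c1ccc(-c2ccc3cccc(F)c3c2)[nH]c1=O` gives 5 nM in an assay on CHO cells for displacement of a labelled ligand from prostaglandin E2 receptor EP3 subtype (Homo sapiens), read by radioligand binding; a higher number here means a weaker inhibitor, a lower number a stronger inhibitor. That is the lowest of the two numbers at hand, but its nearest neighbour, compound 1 `CC(C)C(Nc1nccs1)c1ccc(-c2ccc3cccc(F)c3c2)[nH]c1=O`, gives 9.4 nM in this assay, and the two cannot be told apart, since a 1.9-fold lower number from compound 1 to compound 2 (0.27 log units; within the scatter). Compound 3 `Cc1c[nH]c(C(c2ccc(-c3ccc4cccc(F)c4c3)[nH]c2=O)C(C)C)n1` differs from compound 2 in one place: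

4-methyl-1H-imidazol-2-yl in place of carbamoylmethyl on a saturated chain carbon bound to an aromatic carbon and a saturated chain carbon

Going by the values given here, the only measured step, a 1.9-fold lower number from compound 1 to compound 2 (0.27 log units; within the scatter), exchanged the group on that same saturated chain carbon and stayed within the scatter. No step beyond the scatter is known for a change at this place, so compound 3 is expected to land close to compound 2, with the step of a 1.4-fold higher number from compound 2 to compound 3 (0.15 log units; within the scatter) expected to remain within the usual scatter. In this assay compound 3 is therefore estimated at 7 nM, with a likely range from 2 nM to 25 nM.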

Compound 3, inhibition constant: 12 nM
Beside the measured number, compound 3's estimate is 1.7-fold (0.23 log units) below it, within the range that was stated.
By their numbers in this assay, from the lowest: compounds 2, 1 and 3 (each within the scatter of the next, the first and the last beyond it).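

In this assay, the saturated chain carbon bound to an aromatic carbon and a saturated chain carbon now gives its first step beyond the scatter, a modest one: a 2.4-fold higher number from compound 2 to compound 3 (0.38 log units; beyond the scatter). The 4-methyl-1H-imidazol-2-yl group nevertheless stays within the scatter of the (1,3-thiazol-2-yl)amino group, with a 1.3-fold higher number from compound 1 to compound 3 (0.11 log units; within the scatter), so a change at this place can separate two groups while the overall spread among the three remains small. No measurement on these compounds accounts for the step from carbamoylmethyl to the methylimidazole.

The compounds shown leave open whether an amine or a carboxylic acid on this carbon would keep the number in the same range. Also open, from the compounds shown here alone, is whether the plain imidazol-2-yl group, without its methyl, would match compound 3.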